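From 4-bromophenyl to 3,5-difluorophenyl at the assay limit

The source may report more compounds than this note shows. Statements on the series, on what has been measured and on what is new or still open speak of the compounds shown alone.

In a functional assay on SW-620 cells (Homo sapiens) for antiproliferative activity, read by MTT assay, with a stated time of 72 h (on this read-out higher numbers stand for weaker inhibition and lower numbers for stronger inhibition), compound 1 (`O=C1O/C(=C\Cn2cc(-c3ccc(Br)cc3)nn2)C(OCc2ccccc2)=C1OCc1ccccc1`) gives only a limit, > 100000 nM. Compound 3 (`Cc1ccc(-c2cn(C/C=C3\OC(=O)C(OCc4ccccc4)=C3OCc3ccccc3)nn2)cc1`) also gives only a limit, > 100000 nM. Compound 1 therefore stands at the limit of > 100000 nM in this assay, at which 2 of the 3 values shown sit. Compound 2 (`O=C1O[C@H]([C@@H](O)Cn2cc(-c3ccc(Br)cc3)nn2)C(OCc2ccccc2)=C1OCc1ccccc1`) gives a number, 3760 nM. Compound 4 (`O=C1O/C(=C\Cn2cc(-c3cc(F)cc(F)c3)nn2)C(OCc2ccccc2)=C1OCc1ccccc1`) carries 3,5-difluorophenyl in place of 4-bromophenyl on an aromatic carbon, with 3,5-difluorophenyl in place of 4-bromophenyl on an aromatic carbon. Going by the values given here, the one measured step bearing on this change, methyl in place of bromo, is a step that the two limits leave unreadable from compound 1 to compound 3, so it offers no size and no direction. Compound 4 is therefore expected to stay near the same limit in this assay, with no readable direction. The estimated step is a number no higher from compound 1 to compound 4 (the limit leaves the size open). Compound 4 is expected at 100000 nM, with an estimated range of 20000 nM to 200000 nM.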

Compound 4, half-maximal inhibitory concentration: > 100000 nM
Compound 4 was reported as a limit; the forecaster's own chance of this, stated with the estimate: 70%; the middle value sits exactly at the limit.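

Going by these compounds alone, compound 4 is reported only as a limit, as are compound 1 and compound 3, so no step among them can be read: the limit of > 100000 nM in this assay, at which 3 of the 4 values shown sit. From the compounds shown here alone, the direction and size of any effect of changing the aryl group in this assay stay open.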